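The source may report more compounds than this note shows. Statements on the series, on what has been measured and on what is new or still open speak of the compounds shown alone.

Working notes on the series. Two compounds have a number in a functional assay on PC-3 cells (Homo sapiens) for antiproliferative activity, read by MTT assay, tested at 5 uM; on this read-out lower numbers stand for a weaker effect and higher numbers for a stronger effect at the one concentration tested. Compound 1 `COc1cc(C2=NN(C(C)=O)C(c3c(Cl)cccc3Cl)O2)cc(OC)c1OC` gives -2.2% in this assay. Compound 2 `COc1cc(C2=NN(C(C)=O)C(c3ccccc3C(F)(F)F)O2)cc(OC)c1OC` gives 15.2% in this assay, and on the two numbers at hand compound 2 stands highest, with compound 1 the nearest and only other point, a step of a number 17.4 percentage points higher from compound 1 to compound 2 (beyond the scatter) separating them. Compound 3 `COc1cc(C2=NN(C(C)=O)C(c3ccc(Cl)c(Cl)c3)O2)cc(OC)c1OC` is not yet measured in this assay. It differs from compound 2 in one place: 3,4-dichlorophenyl in place of 2-(trifluoromethyl)phenyl on a saturated ring carbon. Going by the values given here, the only measured step that bears on it is the change of the aryl group on the same saturated ring carbon, a number 17.4 percentage points higher from compound 1 to compound 2 (beyond the scatter), which was modest and beyond the scatter; it concerns a different aryl group than the one entering, so it sets a size but not a direction for the present change. For compound 3 an estimated step of a number 4.8 percentage points higher from compound 2 to compound 3 (within the scatter) is therefore carried, which is not expected to reach beyond the scatter. On this basis compound 3 is expected to give 20% in this assay, with a range from 0% to 45%.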

Compound 3, a percentage reported as inhibition, at one concentration (the size of the read-out at that concentration, not a potency): 26.1%
Compound 3: the middle estimate sits 6.1 percentage points below what was measured, and the stated range covers the measured number.
By their numbers in this assay, from the lowest: compound 1; then compound 2; then compound 3.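

Going by these compounds alone, this position now shows that moving the chlorines alone can shift the read-out: with two dichlorophenyl isomers on the same saturated ring carbon, this assay gives a number 28.3 percentage points higher from compound 1 to compound 3 (beyond the scatter), the largest step so far. The earlier pair changed both the substituent and its pattern, so it could not show this separation, and the new comparison also yields a number 10.9 percentage points higher from compound 2 to compound 3 (beyond the scatter), placing 3,4-dichlorophenyl above 2-(trifluoromethyl)phenyl, with both steps beyond the scatter and compound 3 highest of the three. Nothing available explains why this aryl group gives the higher number, so the ranking stands as an observation on three compounds only.

Open, from the compounds shown here alone, is how an unsubstituted phenyl, or an aryl group carrying an amine or a carboxylic acid, would fall relative to these three halogen-bearing groups at the same ring carbon. Also open, going by these compounds, is whether the order among the aryl groups would hold with a longer chain such as propanoyl in place of the acetyl group, and whether it would persist at other concentrations, since each number here reflects a single tested concentration rather than a potency.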